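Adding a Hydroxy Group to a Cytotoxicity Probe

This account rests on a few compounds, and the source may have more. Where it says the series, first, only, none or still open, it means among the compounds named here.

Compound 2 `C=C1[C@](C)(O)CC[C@@]1(C)c1ccc(C)cc1` was tested in a functional assay on HeLa cells (Homo sapiens) for cytotoxicity, read by MTT assay; on this read-out lower numbers stand for stronger inhibition and higher numbers for weaker inhibition. In this assay compound 2 gives only a limit, > 10 ug/mL, rather than a measured number. Its close relative compound 1 `C=C1[C@](C)(O)CC[C@@]1(C)c1ccc(C)c(O)c1` carries a hydroxy group on an aromatic carbon; in this assay compound 1 likewise gives only a limit, > 10 ug/mL. The step that the two limits leave unreadable from compound 1 to compound 2 therefore cannot be sized, since both of its ends are limits, and the limit of > 10 ug/mL in this assay, at which 2 of the 2 values shown sit, is all that the measurements so far offer.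

Compound 3 `C=C1[C@](C)(O)CC[C@@]1(C)c1ccc(C)cc1O` differs from compound 2 in a single place: hydroxy in place of hydrogen on an aromatic carbon. For the measured compounds named here, the only measured step, the one from compound 1 to compound 2, also concerns a hydroxy group, but its size is not readable, so no measured step gives a direction or a magnitude for this change. Compound 3 is therefore expected to sit at the limit as well, and the expected step that the limit leaves unreadable from compound 2 to compound 3 is none beyond the scatter. The estimate for compound 3 in this assay is 20 ug/mL, with a range from 8 ug/mL to 60 ug/mL.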

Compound 3, half-maximal inhibitory concentration: > 10 ug/mL
Compound 3 ended at the assay's limit; the forecaster's own chance of this, stated with the estimate: 80%; the middle value lies beyond the limit too.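

For the compounds shown here, compound 2 and compound 3 both end as limits in this assay, and no step between them can be read. All the compounds shown share one result: the limit of > 10 ug/mL in this assay, at which 3 of the 3 values shown sit. They leave open whether a hydroxy group on an aromatic carbon changes cytotoxicity at all, and if it does, in which direction and by how much.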